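A few compounds are considered here, and "the series" means these few. Any claim that something is new, unique, unknown or untested is made for them only; others in the source may bear on it.

Compound 1 `CC1C(=O)CC(c2ccc(Cl)cc2)N(C(=O)CN2CCN(C)CC2)C1c1ccc(N(C)C)cc1`: 28.1%
Compound 2 `CC1C(=O)CC(c2ccc(Cl)cc2)N(C(=O)CCl)C1c1ccc(O)cc1`: 39.7%
Compound 3 `CC1C(=O)CC(c2ccc(F)cc2)N(C(=O)CCl)C1c1ccc(O)cc1`: 51.2%

Of the compounds shown here, three have so far been measured in a functional assay on the whole organism for inhibition, with Mus musculus as the target, in the writhing test, with a stated time of 1 h, at a dose of 60 mg/kg by the oral route; a higher number here means more inhibition at the dose given (going by the name of the read-out), a lower number less inhibition. Compound 2 gives 39.7%, the second highest of the three numbers; compound 3 gives 51.2%, and compound 1 gives 28.1%. Among the compounds with values here, only one pair of measured compounds differs in a single place, and that pair shows a number 11.5 percentage points higher from compound 2 to compound 3 (beyond the scatter), a modest rise beyond the scatter.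

Compound 4 `CC1C(=O)CC(c2ccc(Cl)cc2)N(C(=O)CCl)C1c1ccc(N(C)C)cc1` has not yet been measured. It differs from compound 2 in one place: dimethylamino in place of hydroxy on an aromatic carbon. Everything else in compound 2 is kept.

Within the data shown here, no measured step bears on this change. Among the measured compounds shown here, the one recorded step, from compound 2 to compound 3, concerns fluoro in place of chloro, a different group altogether, so it gives no guide here. For the measured compounds named here, compound 1 also carries dimethylamino, but it differs from compound 2 in two places, so its value shows only that a compound with this group can sit lower than compound 2.

With nothing directly comparable, compound 4 is expected to give about 35%, in a range from 15% to 55%. The expected step, a number 4.7 percentage points lower from compound 2 to compound 4 (within the scatter), is estimated to fall within the usual scatter, in no clear direction.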

Compound 4, a percentage reported as inhibition, in the whole organism at one dose (the size of the read-out at that dose, not a potency): 17.8%
Compound 4: middle estimate off by 17.2 percentage points, on the high side; the measured number falls inside the stated range.
By their numbers in this assay, from the lowest: compound 4; then compound 1; then compound 2; then compound 3.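

In this assay, replacing 4-hydroxyphenyl with 4-(dimethylamino)phenyl gives a number 21.9 percentage points lower from compound 2 to compound 4 (beyond the scatter), so the group on this aromatic carbon, para to a large group, clearly matters for the read-out in this series. Compound 4 also links two compounds that could not be compared before: with dimethylamino held constant, a number 10.3 percentage points lower from compound 1 to compound 4 (beyond the scatter) shows that the group on the saturated chain carbon matters too, with 4-methylpiperazin-1-yl giving the higher number in this pair. The hydroxy-to-dimethylamino change removes a hydrogen-bond donor and adds heavy atoms, but nothing here shows which of these differences, if either, accounts for the drop.

A methoxy or a plain amino group on the same aromatic carbon could help separate the loss of the donor from the increase in group size, since only hydroxy and dimethylamino appear there so far. Within the data shown here, it also remains open whether 4-methylpiperazin-1-yl in place of chloro would give a similar step in a compound carrying hydroxy, as the one available comparison carries dimethylamino.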